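From Methoxy to Trifluoromethyl: One Unmeasured Step

This account rests on a few compounds, and the source may have more. Where it says the series, first, only, none or still open, it means among the compounds named here.

- Compound 1 `CCCCc1ccc2[nH]c(-c3ccc(C(F)(F)F)cc3)c(/C=N/NC(=O)c3ccccc3)c2c1`: 460 nM
- Compound 2 `CCCCc1ccc2[nH]c(-c3ccc(OC)cc3)c(/C=N/NC(=O)c3ccc(Cl)cc3)c2c1`: 220 nM

In a functional assay on MCF7 cells (Homo sapiens) for antiproliferative activity, with a stated time of 5 days (a higher number here means a weaker inhibitor, a lower number a stronger inhibitor), compound 2 has the lower number of the two at 220 nM, and compound 1 reads 460 nM, a gap beyond the usual scatter. Compound 3 `CCCCc1ccc2[nH]c(-c3ccc(C(F)(F)F)cc3)c(/C=N/NC(=O)c3ccc(Cl)cc3)c2c1` differs from compound 2 by trifluoromethyl in place of methoxy on an aromatic carbon. Going by the values given here, no measured pair isolates this change. Compound 1 also carries trifluoromethyl and gives 460 nM, so a small move towards a higher number is expected, a 1.4-fold higher number from compound 2 to compound 3 (0.13 log units; within the scatter), probably within the scatter. Compound 3 is estimated at 300 nM, with an expected range from 120 nM to 700 nM.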

Compound 3, half-maximal inhibitory concentration: 1060 nM
The estimate for compound 3 lay 3.5-fold (0.55 log units) below the measured number, and the stated range ends below it.
By their numbers in this assay, from the lowest: compound 2; then compound 1; then compound 3.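

In this assay, the change from 4-methoxyphenyl to 4-(trifluoromethyl)phenyl now has a measured size with the chloro kept in place (a 4.8-fold higher number from compound 2 to compound 3 (0.68 log units; beyond the scatter)), so this position responds clearly to the swap. With trifluoromethyl kept, chloro in place of hydrogen moves the number the same way (a 2.3-fold higher number from compound 1 to compound 3 (0.36 log units; beyond the scatter)), so the chloro does not help in this setting. Nothing at hand accounts for either step. Still open, on these data alone, is how chloro in place of hydrogen reads alongside methoxy, and how an amine or a hydroxyl group would read in place of trifluoromethyl.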